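Ethoxycarbonyl to Phenylcarbamoyl: An Expected Shift in Growth Inhibition

This account rests on a few compounds, and the source may have more. Where it says the series, first, only, none or still open, it means among the compounds named here.

Compound 3 `CCOC(=O)C1=C(C)NC(=S)NC1c1cn(-c2ccccc2)nc1-c1ccc(Cl)cc1` gives 33200 nM in a functional assay on MCF7 cells (Homo sapiens) for inhibition, read by sulforhodamine B assay, with a stated time of 24 h; a higher number here means a weaker inhibitor of growth, a lower number a stronger inhibitor of growth. Among the three compounds measured so far it holds the lowest number, though compound 1 `CCOC(=O)C1=C(C)NC(=S)NC1c1cn(-c2ccccc2)nc1-c1ccccc1`, with 42000 nM, lies within the scatter of it, so no order between those two can be drawn; only compound 2 `CC1=C(C(=O)Nc2ccccc2)C(c2cn(-c3ccccc3)nc2-c2ccccc2)NC(=S)N1`, at 88200 nM, stands clearly apart. The step of a 1.3-fold lower number from compound 1 to compound 3 (0.10 log units; within the scatter) is the same chloro substitution that separates compound 3 from compound 1.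

Compound 4 `CC1=C(C(=O)Nc2ccccc2)C(c2cn(-c3ccccc3)nc2-c2ccc(Cl)cc2)NC(=S)N1` differs from compound 3 by anilino in place of ethoxy on a carbonyl carbon. Among the measured compounds shown here, the one measured step that bears on this change is a 2.1-fold higher number from compound 1 to compound 2 (0.32 log units; beyond the scatter), the same exchange made on the compound lacking the chloro group. Going by that step, a modest rise of similar size is expected for compound 4 in this assay, which would put a 2.1-fold higher number from compound 3 to compound 4 (0.32 log units; beyond the scatter). For the measured compounds named here, whether the chloro group alters how far the exchange carries is not told by the data: only one such step exists. Compound 4 is therefore estimated at 70000 nM, with a range from 35000 nM to 140000 nM.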

Compound 4, concentration for 50% growth inhibition: 61500 nM
Compound 4: the middle estimate sits 1.1-fold (0.06 log units) above what was measured, and the stated range covers the measured number.
By their numbers in this assay, from the lowest: compounds 3, 1, 4 and 2 (each within the scatter of the next, the first and the last beyond it).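

Compound 4 lets the exchange of ethoxycarbonyl for phenylcarbamoyl be read on a second core in this assay, where it gives a 1.9-fold higher number from compound 3 to compound 4 (0.27 log units; within the scatter); taken alone this step does not clear the scatter, but its size agrees with that of the exchange on the core without the chloro group: the same change on two cores in this assay, a 2.1-fold higher number (0.32 log units; beyond the scatter) from compound 1 to compound 2 and a 1.9-fold higher number (0.27 log units; within the scatter) from compound 3 to compound 4, 1.1-fold (0.05 log units) apart, within the scatter of two such steps. Compound 4 also gives a second reading of chloro in place of hydrogen on an aromatic carbon, a 1.4-fold lower number from compound 2 to compound 4 (0.16 log units; within the scatter), so this change stays within the scatter on the anilide core as it did on the ester core: the same change on two cores in this assay, a 1.3-fold lower number (0.10 log units; within the scatter) from compound 1 to compound 3 and a 1.4-fold lower number (0.16 log units; within the scatter) from compound 2 to compound 4, 1.1-fold (0.05 log units) apart, within the scatter of two such steps. Within these four compounds, each change therefore has much the same size whichever form the other place takes, and the two show no sign of depending on each other.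

The compounds shown compare only ethoxy and anilino on this carbonyl carbon, so it remains open how a smaller amine such as methylamino, a saturated ring amine such as morpholine, or a free carboxylic acid would read there. Chloro is also the only group set against hydrogen on the aromatic ring, which leaves groups such as methoxy or fluoro open.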